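A few compounds are considered here, and "the series" means these few. Any claim that something is new, unique, unknown or untested is made for them only; others in the source may bear on it.

Compound 1 `O=C(Nc1nc2ccc(Cl)cc2s1)c1cn(-c2ccccc2)nc1-c1ccc(F)cc1` is tested in an ADME assay on HEK-293T cells (Homo sapiens) for cytotoxicity, read by MTT assay, with a stated time of 72 h (on this read-out lower numbers stand for stronger inhibition and higher numbers for weaker inhibition), where compound 1 gives 45700 nM. Compound 2 `COc1ccc2nc(NC(=O)c3cn(-c4ccccc4)nc3-c3ccc(F)cc3)sc2c1` carries methoxy in place of chloro on an aromatic carbon; in this assay compound 2 reaches only the limit of the measurement, > 50000 nM, so no number is known for it, and the step is an at least 1.0-fold higher number from compound 1 to compound 2 (0.03 log units; that floor lies within the scatter). Compound 3 `COc1ccc(-c2nn(-c3ccccc3)cc2C(=O)Nc2nc3ccc(Cl)cc3s2)cc1` differs from compound 1 by methoxy in place of fluoro on an aromatic carbon, and in this assay compound 3 gives 12600 nM, the step being a 3.6-fold lower number from compound 1 to compound 3 (0.56 log units; beyond the scatter). Compound 4 `COc1ccc(-c2nn(-c3ccccc3)cc2C(=O)Nc2nc3ccc(OC)cc3s2)cc1` has not yet been measured. It differs from compound 3 by methoxy in place of chloro on an aromatic carbon, the same change as that from compound 1 to compound 2. By analogy with that earlier step, the estimated step is a 1.6-fold higher number from compound 3 to compound 4 (0.20 log units; within the scatter), an expectation resting on an at least 1.0-fold higher number from compound 1 to compound 2 (0.03 log units; that floor lies within the scatter). Compound 4 is therefore expected to give about 20000 nM in this assay.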

Compound 4, half-maximal inhibitory concentration: > 50000 nM
Compound 4: no number, only a limit (the forecaster's own chance of this, stated with the estimate: 15%); at least 2.5-fold (0.39 log units) between middle value and limit.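

Replacing 6-chloro-1,3-benzothiazol-2-yl with 6-methoxy-1,3-benzothiazol-2-yl on the core of compound 3 gives, in this assay, an at least 3.9-fold higher number from compound 3 to compound 4 (0.59 log units; beyond the scatter). This shows that the change can raise the number on this core, but not that it acts equally or differently on the two cores: the same change on two cores in this assay, an at least 1.0-fold higher number (0.03 log units; that floor lies within the scatter) from compound 1 to compound 2 and an at least 3.9-fold higher number (0.59 log units; beyond the scatter) from compound 3 to compound 4; the limit leaves it open whether they differ. Compound 2 and compound 4 both stop at a limit rather than a number, which leaves the full size of each step unknown and the step between these two compounds unreadable: the limit of > 50000 nM in this assay, at which 2 of the 4 values shown sit.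

The compounds shown leave open how this position would respond if an amine, a carboxylic acid or a longer chain such as ethoxy replaced chloro. They also leave open whether the step would carry over to a core with an amine in place of the fluoro or methoxy group.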